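Sulfonyl Aryl Exchange: From Isopropylphenyl to Naphthyl

This account rests on a few compounds, and the source may have more. Where it says the series, first, only, none or still open, it means among the compounds named here.

Measured in an assay on Sf9 cells for inhibition of mitogen-activated protein kinase kinase kinase 20 (Homo sapiens), read by ADP-Glo, with a stated time of 30 min; a higher number here means a weaker inhibitor, a lower number a stronger inhibitor:
compound 1 `COc1n[nH]c2ncc(-c3cn(-c4c(F)ccc(NS(=O)(=O)c5cccc(Br)c5)c4F)nn3)cc12`: 2.1 nM
compound 2 `COc1cccc(S(=O)(=O)Nc2ccc(F)c(-n3cc(-c4cnc5[nH]nc(OC)c5c4)nn3)c2F)c1`: 2.3 nM
compound 3 `COc1n[nH]c2ncc(-c3cn(-c4c(F)ccc(NS(=O)(=O)c5cccc(C(C)C)c5)c4F)nn3)cc12`: 6.9 nM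

Compound 3 carries the highest number of the three in this assay. The nearest value belongs to compound 2, the step being a 3.0-fold higher number from compound 2 to compound 3 (0.48 log units; beyond the scatter), and the furthest to compound 1, with a 3.3-fold higher number from compound 1 to compound 3 (0.52 log units; beyond the scatter). Compound 4 `COc1n[nH]c2ncc(-c3cn(-c4c(F)ccc(NS(=O)(=O)c5cccc6ccccc56)c4F)nn3)cc12` differs from compound 3 by naphthalen-1-yl in place of 3-isopropylphenyl on a sulfonyl sulfur. Among the compounds with values here, no measured step bears directly on this exchange; the two steps above show only that the isopropyl variant sits higher than its bromo and methoxy counterparts. The step of a 1.5-fold lower number from compound 3 to compound 4 (0.19 log units; within the scatter) is therefore expected to be small, leaning toward a lower number. Compound 4 is estimated at 4.5 nM, with a range from 1.5 nM to 15 nM.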

Compound 4, half-maximal inhibitory concentration: 4.2 nM
Compound 4: middle estimate off by 1.1-fold (0.03 log units), on the high side; measured number inside the range.
By their numbers in this assay, from the lowest: compounds 1, 2, 4 and 3 (each within the scatter of the next, the first and the last beyond it).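

In this assay, naphthalen-1-yl, with 2 six-membered aromatic rings, sits on the sulfonyl sulfur within the scatter of all three single-ring aryl groups (a 1.6-fold lower number from compound 3 to compound 4 (0.22 log units; within the scatter) and a 1.8-fold higher number from compound 2 to compound 4 (0.26 log units; within the scatter) and a 2.0-fold higher number from compound 1 to compound 4 (0.30 log units; within the scatter)). This position therefore holds a second ring with no step beyond the scatter, even though the 3-bromophenyl and 3-isopropylphenyl compounds lie beyond the scatter of each other. Nothing measured accounts for this. As far as these compounds go, whether naphthalen-2-yl, cyclohexyl, or an aryl group bearing an amine or a carboxylic acid would stay in this range remains open.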